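The compounds below may be only part of what the source reports. "The series", "measured", "known", "first", "only" and "open" are said of these compounds alone.

Of the compounds shown here, two have so far been measured in a functional assay on isolated protein for agonist activity at Glucose-dependent insulinotropic receptor (Rattus norvegicus), read by HTRF and cAMP accumulation; a higher number here means that more compound is needed for the effect, a lower number that less compound is needed. Compound 1 `CC(C)(C)OC(=O)N1CCC(O[C@H]2CC[C@H](Oc3ccc(C#N)cc3)CC2)CC1` gives 45 nM in this assay. Compound 2 `CC(C)S(=O)(=O)c1cnc(O[C@H]2CC[C@H](OC3CCN(C(=O)OC(C)(C)C)CC3)CC2)cn1` gives 54 nM in this assay. These two numbers lie within the usual scatter of each other, so compound 2 cannot be placed apart from compound 1 on this evidence; because the two compounds differ in more than one place, their values show only that both sit in the same range. Compound 3 `CC(C)(C)OC(=O)N1CCC(O[C@H]2CC[C@H](Oc3cnc(C#N)cn3)CC2)CC1` has not yet been measured. It departs from compound 2 by a single exchange: cyano in place of isopropylsulfonyl on an aromatic carbon. Among the measured compounds shown here, no measured pair isolates this exchange, so its effect is not known. Compound 1, which carries the cyano group, gives 45 nM, and compound 2, which carries the isopropylsulfonyl group, gives 54 nM. On this basis the step from compound 2 to compound 3 is expected to be small, a 1.3-fold higher number from compound 2 to compound 3 (0.11 log units; within the scatter), and not beyond the scatter in either direction. Compound 3 is therefore estimated at 70 nM in this assay, with a range from 25 nM to 200 nM.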

Compound 3, half-maximal effective concentration: 28.4 nM
Compound 3: middle estimate off by 2.5-fold (0.39 log units), on the high side, and the stated range covers the measured number.
By their numbers in this assay, from the lowest: compounds 3, 1 and 2 (each within the scatter of the next).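

With the pair now in hand, the exchange of isopropylsulfonyl for cyano at this aromatic carbon, on the six-membered aromatic ring with 2 nitrogen, can be read directly in this assay: it gives a 1.9-fold lower number from compound 2 to compound 3 (0.28 log units; within the scatter), so a group of 6 heavy atoms and one of 2 heavy atoms cannot be told apart at this place. The other exchange, 5-cyanopyrazin-2-yl in place of 4-cyanophenyl on the oxygen, gives a 1.6-fold lower number from compound 1 to compound 3 (0.20 log units; within the scatter), so with the cyano group present, this change of ring also leaves the number within the scatter. No measurement is available that bears on the reason for either result.

The compounds shown leave open whether an amine or a carboxylic acid on this aromatic carbon would stay in the same range, as the only groups compared here are cyano and isopropylsulfonyl. They also leave open whether isopropylsulfonyl in place of cyano on the ring of compound 1 would behave as it does on the ring of compound 3.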